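Boc removal on the cyclohexene amine: cytotoxicity notes

The compounds below may be only part of what the source reports. "The series", "measured", "known", "first", "only" and "open" are said of these compounds alone.

Measured so far:
- compound 1 `CCC(CC)O[C@@H]1C=C(C(=O)Nc2ccccc2)C[C@H](N)[C@H]1NC(C)=O`: 375000 nM
- compound 2 `CCC(CC)O[C@@H]1C=C(C(=O)Nc2ccccc2OC)C[C@H](NC(=O)OC(C)(C)C)[C@H]1NC(C)=O`: > 1000000 nM
- compound 3 `CCC(CC)O[C@@H]1C=C(C(=O)Nc2ccccc2)C[C@H](NC(=O)OC(C)(C)C)[C@H]1NC(C)=O`: > 1000000 nM

In an ADME assay on HeLa cells (Homo sapiens) for cytotoxicity, with a stated time of 24 h (on this read-out higher numbers stand for lower toxicity in this test and lower numbers for higher toxicity in this test), compound 3 reaches only a limit of the assay, > 1000000 nM. For compound 2 the read-out in this assay is likewise a limit, > 1000000 nM, so two of the three values sit at the limit of > 1000000 nM in this assay, at which 2 of the 3 values shown sit. Compound 1 gives a number, 375000 nM, and the change hydrogen in place of tert-butoxycarbonyl on an amine nitrogen made an at least 2.6-fold lower number from compound 3 to compound 1 (0.42 log units; beyond the scatter).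

The cores of compound 2 and compound 3 differ by methoxy in place of hydrogen on an aromatic carbon; the step that the two limits leave unreadable from compound 2 to compound 3.

Compound 4 `CCC(CC)O[C@@H]1C=C(C(=O)Nc2ccccc2OC)C[C@H](N)[C@H]1NC(C)=O` is not yet measured. It differs from compound 2 by hydrogen in place of tert-butoxycarbonyl on an amine nitrogen, the same change as from compound 3 to compound 1. In this assay the expected step is an at least 2.5-fold lower number from compound 2 to compound 4 (0.39 log units; beyond the scatter), resting on the measured at least 2.6-fold lower number from compound 3 to compound 1 (0.42 log units; beyond the scatter). Compound 4 is estimated at 400000 nM, between 150000 nM and 1000000 nM.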

Compound 4, half-maximal cytotoxic concentration: 155000 nM
Estimate against measurement, compound 4: 2.6-fold (0.41 log units) above, within the range that was stated.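

In this assay, hydrogen in place of tert-butoxycarbonyl on an amine nitrogen gives an at least 6.4-fold lower number from compound 2 to compound 4 (0.80 log units; beyond the scatter). The change lowers the number on both cores, so its direction carries over between these two pairs: the same change on two cores in this assay, an at least 2.6-fold lower number (0.42 log units; beyond the scatter) from compound 3 to compound 1 and an at least 6.4-fold lower number (0.80 log units; beyond the scatter) from compound 2 to compound 4; the limit leaves it open whether they differ It does not show whether the size carries over, since compound 2 and compound 3 both sit at the assay limit, and the step between those two cannot be read.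

As far as these compounds go, with the free amine, methoxy in place of hydrogen on an aromatic carbon gives a 2.4-fold lower number from compound 1 to compound 4 (0.38 log units; beyond the scatter), and whether this holds on other cores stays open. Also open, from the compounds shown here alone, is what an acetyl group on that amine nitrogen, or a longer alkoxy chain in place of methoxy, would do to the number.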